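The compounds below may be only part of what the source reports. "The series", "measured", "known", "first", "only" and "open" are said of these compounds alone.

Of the compounds shown here, three have been measured in a functional assay on A375P cells (Homo sapiens) for antiproliferative activity, read by MTT assay, with a stated time of 48 h; on this read-out higher numbers stand for weaker inhibition and lower numbers for stronger inhibition.
Compound 1 `CC(=O)Nc1cccc2c(-c3cccc(NC(=O)c4ccc(C)c(C)c4)c3)ccnc12` gives > 20000 nM, which is a limit of the assay rather than a number.
Compound 2 `CC(=O)Nc1cccc2c(-c3cccc(NC(=O)c4ccc(Cl)cc4C(F)(F)F)c3)ccnc12` gives > 20000 nM, again a limit.
Compound 3 `CC(=O)Nc1cccc2c(-c3cccc(NC(=O)c4cc(Cl)cc(C(F)(F)F)c4)c3)ccnc12` gives 6200 nM.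

Among the compounds with values here, compound 3 therefore holds the only number among the three values; the other two sit at the limit of > 20000 nM in this assay, at which 2 of the 3 values shown sit. The two steps that lead to it are an at least 3.2-fold lower number from compound 1 to compound 3 (0.50 log units; beyond the scatter) and an at least 3.2-fold lower number from compound 2 to compound 3 (0.50 log units; beyond the scatter), so of the three aryl groups tried on the carbonyl carbon, the 3-chloro-5-(trifluoromethyl)phenyl is the one that yields a readable value in this assay.

Compound 4 `CC(=O)Nc1cccc2c(-c3cccc(NC(=O)c4ccc5c(c4)OCCO5)c3)ccnc12` carries the change (2,3-dihydro-1,4-benzodioxin-6-yl in place of 3-chloro-5-(trifluoromethyl)phenyl on a carbonyl carbon). Within the data shown here, no measured step involves the 2,3-dihydro-1,4-benzodioxin-6-yl group, so the expectation rests on the observation that both other aryl groups on that carbonyl carbon, in compound 1 and compound 2, returned limits; no measured compound goes against this. The expected step is a 2.4-fold higher number from compound 3 to compound 4 (0.38 log units; beyond the scatter), back toward the limit of this assay. Compound 4 is estimated at 15000 nM, with a range from 5000 nM to 40000 nM, and a substantial chance that only a limit is returned.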

Compound 4, half-maximal inhibitory concentration: 570 nM
The estimate for compound 4 lay 26-fold (1.42 log units) above the measured number; the measured number lies below the stated range.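

In this assay, the place on the carbonyl carbon turns out to tolerate far more than the first three compounds suggested: the change to 2,3-dihydro-1,4-benzodioxin-6-yl gives an 11-fold lower number from compound 3 to compound 4 (1.04 log units; beyond the scatter). Within the data shown here, the only readable value had so far belonged to a group carrying chlorine and trifluoromethyl, whereas this group has neither and brings in oxygen, so neither of those substituents is needed for a readable value here, and compound 4 now has the lowest number of the four. The same group also gives an at least 35-fold lower number from compound 2 to compound 4 (1.54 log units; beyond the scatter) and an at least 35-fold lower number from compound 1 to compound 4 (1.54 log units; beyond the scatter), but compound 1 and compound 2 each stand at a limit and not at a number, so these two steps give only a bound on the true size: the limit of > 20000 nM in this assay, at which 2 of the 4 values shown sit.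

The compounds shown leave open whether the gain comes from the two oxygen atoms or from the closed non-aromatic ring itself, which a plain methoxy group on the phenyl ring could help to separate. They also leave open how an amine such as morpholine or a carboxylic acid would behave on this carbonyl carbon.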